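Triazole for Phenyl at the Chain End: Compound 4

The compounds below may be only part of what the source reports. "The series", "measured", "known", "first", "only" and "open" are said of these compounds alone.

Measured so far:
compound 1 `CCCCNc1nc(N)nc(C)c1CCCN1CCN(C)CC1`, 179 nM
compound 2 `CCCCNc1nc(N)nc(C)c1CCCC(C)(C)O`, 1220 nM
compound 3 `CCCCNc1nc(N)nc(C)c1CCCc1ccccc1`, 749 nM

The three compounds share one core and differ only in the group placed on a saturated chain carbon, three bonds along the chain from an aromatic carbon. In an assay on HEK293 cells for agonist activity at Toll-like receptor 8 (Homo sapiens), read by spectrophotometry (on this read-out lower numbers stand for an effect already at smaller amounts and higher numbers for an effect only at larger amounts of compound), compound 1 gives the lowest number of the three, and compound 3 stands second highest. Its nearest neighbour is compound 2, with a 1.6-fold lower number from compound 2 to compound 3 (0.21 log units; within the scatter), a gap that stays within the scatter. Its furthest is compound 1, with a 4.2-fold higher number from compound 1 to compound 3 (0.62 log units; beyond the scatter), a gap that lies beyond it. The third step, a 6.8-fold higher number from compound 1 to compound 2 (0.83 log units; beyond the scatter), likewise goes beyond the scatter.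

Compound 4 `CCCCNc1nc(N)nc(C)c1CCCn1cncn1` carries the change (1H-1,2,4-triazol-1-yl in place of phenyl on a saturated chain carbon, three bonds along the chain from an aromatic carbon). Going by the values given here, no measured step exchanges one aromatic ring for another at this place, so the comparison rests on the pattern above: only the move away from the 4-methylpiperazin-1-yl group of compound 1 shifted the number beyond the scatter, while the exchange of a 1-hydroxy-1-methylethyl group for phenyl did not. Both the leaving phenyl and the entering triazolyl group carry no net charge. Compound 4 is therefore expected to show no step beyond the scatter, a 1.1-fold higher number from compound 3 to compound 4 (0.03 log units; within the scatter). The estimate for compound 4 is 800 nM, with a range from 250 nM to 2500 nM.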

Compound 4, half-maximal effective concentration: 1050 nM
Compound 4: the middle estimate sits 1.3-fold (0.12 log units) below what was measured, within the range that was stated.
By their numbers in this assay, from the lowest: compound 1; then compounds 3, 4 and 2 (each within the scatter of the next).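

In this assay, 1H-1,2,4-triazol-1-yl differs from phenyl in ring size and brings hetero atoms and hydrogen-bond acceptors, yet the exchange gives a 1.4-fold higher number from compound 3 to compound 4 (0.15 log units; within the scatter) and so leaves the number within the scatter at this place. The comparison with the 1-hydroxy-1-methylethyl group gives a 1.2-fold lower number from compound 2 to compound 4 (0.07 log units; within the scatter), which means that compound 2, compound 3 and compound 4 now stand within the scatter of one another, although their end groups are an open-chain alcohol, a carbon-only aromatic ring and a nitrogen-rich aromatic ring. The 4-methylpiperazin-1-yl group stays apart from all three, and the third new step, a 5.9-fold higher number from compound 1 to compound 4 (0.77 log units; beyond the scatter), confirms that this separation holds for a further end group.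

No measurement at hand accounts for the lower number of compound 1 or for the closeness of the other three. As far as these compounds go, whether a dimethylamino group or a morpholin-4-yl group at the same place would keep the number of compound 1 or join the other three remains open, as does the effect of a longer chain carrying the 4-methylpiperazin-1-yl group.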